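The source may hold more compounds than are shown below. What is called first, only, known or untested is meant among the compounds shown, and "the series" means these compounds.

Measured so far in a functional assay on J774 cells (Mus musculus) for cytotoxicity, read by resazurin assay; on this read-out higher numbers stand for weaker inhibition and lower numbers for stronger inhibition:
Compound 1 `OCCCCCC(O)c1ccc(-c2ccccc2)cc1`: 22000 nM
Compound 2 `Cc1ccccc1-c1ccc(C(O)CCCCCO)cc1`: 24000 nM
Compound 3 `Cc1cc(F)ccc1-c1ccc(C(O)CCCCCO)cc1`: 20000 nM

Compound 2 becomes compound 3 through (fluoro in place of hydrogen on an aromatic carbon), and that change gave a 1.2-fold lower number from compound 2 to compound 3 (0.08 log units; within the scatter). Compound 4 `OCCCCCC(O)c1ccc(-c2ccccc2)c(F)c1` has not been measured in this assay. It is derived from compound 1 by fluoro in place of hydrogen on an aromatic carbon, the same kind of change, though not the same one: the two cores differ by hydrogen in place of methyl on an aromatic carbon, and the surroundings of the place differ as well, the new fluoro being ortho to a phenyl group and meta to a group of 8 heavy atoms in compound 4, but meta to a methyl group and para to a large group in compound 3. The step from compound 1 to compound 4 is therefore expected to be small, about a 1.0-fold lower number from compound 1 to compound 4 (0.02 log units; within the scatter); this expectation rests on the earlier step of a 1.2-fold lower number from compound 2 to compound 3 (0.08 log units; within the scatter), which stayed within the scatter. Compound 4 is estimated at 21000 nM in this assay, with a likely range from 11000 nM to 40000 nM.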

Compound 4, half-maximal inhibitory concentration: 17000 nM
The estimate for compound 4 lay 1.2-fold (0.09 log units) above the measured number; low and high end bracket the measured number.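

In this assay, fluoro in place of hydrogen on an aromatic carbon gave a 1.3-fold lower number from compound 1 to compound 4 (0.11 log units; within the scatter). Set beside the earlier step, the change showed no difference between the two cores: the same change on two cores in this assay, a 1.2-fold lower number (0.08 log units; within the scatter) from compound 2 to compound 3 and a 1.3-fold lower number (0.11 log units; within the scatter) from compound 1 to compound 4, 1.1-fold (0.03 log units) apart, within the scatter of two such steps. This shows that the change stayed small on both cores, but it does not show a real effect of fluoro on either one, and two pairs with the fluoro in different surroundings give no rule for other cores.

The compounds shown leave open what chloro or trifluoromethyl would do in place of fluoro on these cores. They also leave open how a longer chain, or an amine or a carboxylic acid on the chain, would read in this assay.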